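Replacing the furan-bearing group of compound 2

The source may hold more compounds than are shown below. What is called first, only, known or untested is meant among the compounds shown, and "the series" means these compounds.

Compound 1 `NC1CCC(Nc2nc(NCc3ccc(-c4ccccc4)cc3)c3ncn(C4CCCC4)c3n2)CC1`: 1020 nM
Compound 2 `NC1CCC(Nc2nc(NCc3ccc(-c4ccco4)cc3)c3ncn(C4CCCC4)c3n2)CC1`: 164 nM
Compound 3 `CC(C)(O)CNc1nc(NCc2ccc(-c3ccco3)cc2)c2ncn(C3CCCC3)c2n1`: 17400 nM

In a functional assay on G-361 cells (Homo sapiens) for inhibition, with a stated time of 72 h (on this read-out higher numbers stand for weaker inhibition and lower numbers for stronger inhibition), compound 2 has the lowest number of the three, and its gaps to both compound 1 and compound 3 lie beyond the scatter. Compound 4 `NC1CCC(Nc2nc(NCc3ccc(-c4cccs4)nc3)c3ncn(C4CCCC4)c3n2)CC1`, not yet measured, departs from compound 2 by one exchange: 6-(thiophen-2-yl)pyridin-3-yl in place of 4-(furan-2-yl)phenyl on a saturated chain carbon bound to a nitrogen on an aromatic ring.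

Two measured steps can be weighed against this exchange. The more relevant is a 6.2-fold lower number from compound 1 to compound 2 (0.79 log units; beyond the scatter), a modest step made by placing furan-2-yl in place of phenyl on an aromatic carbon, within the same group that compound 4 alters. The other is a 110-fold higher number from compound 2 to compound 3 (2.03 log units; beyond the scatter), a large step. It exchanges the 4-aminocyclohexyl group, which compound 4 retains, so it offers no guide here.

Within the data shown here, no measured compound carries a thiophen-2-yl group or a pyridin-3-yl ring, so the data do not indicate a direction. A change at most comparable to the modest step is expected, and the central expectation lies within the scatter. For compound 4, the expected value in this assay is 150 nM, with an estimated range of 40 nM to 550 nM. The estimate corresponds to an expected 1.1-fold lower number from compound 2 to compound 4 (0.04 log units; within the scatter).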

Compound 4, half-maximal inhibitory concentration: 150 nM
For compound 4 middle estimate and measured number coincide at the digits printed; the measured number falls inside the stated range.
By their numbers in this assay, from the lowest: compounds 4 and 2 (each within the scatter of the next); then compound 1; then compound 3.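

In this assay, the exchange gives a 1.1-fold lower number from compound 2 to compound 4 (0.04 log units; within the scatter), so at this position both rings of the group can change at once, with a nitrogen entering the six-membered ring and sulfur replacing oxygen in the five-membered ring, without a shift beyond the scatter. The exchange from the biaryl group of compound 1 gives a 6.8-fold lower number from compound 1 to compound 4 (0.83 log units; beyond the scatter), a modest step of the same order as a 6.2-fold lower number from compound 1 to compound 2 (0.79 log units; beyond the scatter), so compounds 2 and 4, which each carry a five-membered aromatic ring with one hetero atom, both stand apart from compound 1, which carries 4-phenylphenyl. Nothing available explains why the 4-(furan-2-yl)phenyl and 6-(thiophen-2-yl)pyridin-3-yl groups read alike here.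

What each of the two ring changes contributes alone stays open, since the compounds shown do not separate them: a 4-(thiophen-2-yl)phenyl group or a 6-(furan-2-yl)pyridin-3-yl group would do so. Also open, going by these compounds, is how far this position accepts further change, for instance a methyl group or a carboxylic acid on the five-membered ring, or a thiazole in its place.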